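Swapping a Pentyl Chain for a Cyclohexyl Ring

This account rests on a few compounds, and the source may have more. Where it says the series, first, only, none or still open, it means among the compounds named here.

Measured compounds:
compound 1 `O=C(N/N=C/c1ccc(F)cc1)c1ccc(O[C@@H]2O[C@H](CO)[C@@H](O)[C@H](O)[C@H]2O)cc1` — 9.91%
compound 2 `CCCCCc1nnc(-c2ccc(O[C@@H]3O[C@H](COC(C)=O)[C@@H](OC(C)=O)[C@H](OC(C)=O)[C@H]3OC(C)=O)cc2)o1` — 21.5%
compound 3 `O=C(N/N=C/c1cccc(Cl)c1)c1ccc(O[C@@H]2O[C@H](CO)[C@@H](O)[C@H](O)[C@H]2O)cc1` — 5.02%

In a functional assay on MDA-MB-231 cells (Homo sapiens) for inhibition, read by MTT assay, with a stated time of 24 h, tested at 100 uM (a lower number here means less inhibition, a higher number more inhibition at the concentration tested (going by the name of the read-out)), compound 2 gives 21.5%, the highest of the three numbers, and its distance to compound 1 and to compound 3 is beyond the scatter. Compound 4 `CC(=O)OC[C@H]1O[C@@H](Oc2ccc(-c3nnc(C4CCCCC4)o3)cc2)[C@H](OC(C)=O)[C@@H](OC(C)=O)[C@@H]1OC(C)=O` differs from compound 2 by cyclohexyl in place of pentyl on an aromatic carbon. Among the measured compounds shown here, the only measured step, a number 4.9 percentage points lower from compound 1 to compound 3 (within the scatter), alters a different part of the shared core and within the scatter at that, so it gives no guide to this change. For the measured compounds named here, no measured pair shows what exchanging pentyl for cyclohexyl does here. The step of a number 0.5 percentage points higher from compound 2 to compound 4 (within the scatter) is therefore expected to be none beyond the scatter. Compound 4 is expected to give about 22%, with a range from 10% to 35%.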

Compound 4, a percentage reported as inhibition, at one concentration (the size of the read-out at that concentration, not a potency): 11.6%
Compound 4: middle estimate off by 10.4 percentage points, on the high side; the range from low to high includes it.
By their numbers in this assay, from the lowest: compounds 3, 1, 4 and 2 (each within the scatter of the next, the first and the last beyond it).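

In this assay, among the compounds shown here, the step of a number 9.9 percentage points lower from compound 2 to compound 4 (within the scatter) gives the first measured reading for a change on this aromatic carbon of the five-membered ring. It shows that replacing the open pentyl chain with the cyclohexyl ring, which adds one carbon and closes a ring, does not move the number beyond the usual scatter. No measurement here explains this result. As far as these compounds go, it remains open whether a longer chain, such as octyl, or an amine on this same carbon would give a number beyond the scatter.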